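Solubility on a shared core: from phenoxy to a lactam

The source may hold more compounds than are shown below. What is called first, only, known or untested is meant among the compounds shown, and "the series" means these compounds.

Measured compounds:
- compound 1 `Cc1nccn1-c1cnc(NCc2c(F)ccc3c2CCO3)c2cn[nH]c(=O)c12` gives 7000 nM
- compound 2 `CN(C)C(=O)c1cc(-c2cnc(NCc3c(F)ccc4c3CCO4)c3cn[nH]c(=O)c23)n(C)n1` gives 3000 nM
- compound 3 `Fc1ccc2c(c1CNc1ncc(Oc3ccccc3)c3nncn13)CCO2` gives 8000 nM

These three compounds were measured in a physicochemical assay for solubility, read by LC-MS, in phosphate buffer, with a stated time of 24 h, at pH 7.4; a higher number here means a more soluble compound, a lower number a less soluble compound. Compound 3 stands highest of the three numbers, but compound 1 lies within the scatter of it, so the two cannot be told apart; compound 2 lies beyond the scatter below both. Within the data shown here, the only measured step within this set is a 2.3-fold lower number from compound 1 to compound 2 (0.37 log units; beyond the scatter), where one ring group on an aromatic carbon was exchanged for another, and the number moved modestly.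

Compound 4 `C[C@@H]1CC(=O)N(c2cnc(NCc3c(F)ccc4c3CCO4)n3cnnc23)C1` has not been measured. It differs from compound 3 in one place: 4-methyl-2-oxopyrrolidin-1-yl in place of phenoxy on an aromatic carbon. Among the measured compounds shown here, the step from compound 1 to compound 2 is the only guide, and it shows that swapping a ring group on the core shifts the number only modestly. For compound 4 a step of about a 1.3-fold higher number from compound 3 to compound 4 (0.10 log units; within the scatter) is therefore expected, a small move that may well stay within the scatter. The estimate for compound 4 is 10000 nM, with a range from 4000 nM to 25000 nM.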

Compound 4, solubility: 130000 nM
Estimate against measurement, compound 4: 13-fold (1.11 log units) below; measured number above the stated range.
By their numbers in this assay, from the lowest: compound 2; then compounds 1 and 3 (each within the scatter of the next); then compound 4.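

At this aromatic carbon, 4-methyl-2-oxopyrrolidin-1-yl in place of phenoxy gives a 16-fold higher number from compound 3 to compound 4 (1.21 log units; beyond the scatter) in this assay, so a single exchange here can move the number a long way. Among these compounds, the only earlier step, a 2.3-fold lower number from compound 1 to compound 2 (0.37 log units; beyond the scatter), was modest and lay on a different core, so it gave no sign of a move this large. The two groups have the same counts of heavy atoms, hydrogen-bond donors and hydrogen-bond acceptors; they differ in that a six-membered aromatic ring of carbon only gives way to a five-membered non-aromatic ring with a hetero atom, a double bond outside aromatic rings and a defined stereocentre.

No measurement shown explains the size of this step. As far as these compounds go, it remains open whether the same ring without its methyl, an open-chain amide or an amine at this carbon would give a similar number.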